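Aryl ether change from compound 3 to compound 4

The compounds below may be only part of what the source reports. "The series", "measured", "known", "first", "only" and "open" are said of these compounds alone.

Measured in a functional assay on HEK293 cells for positive allosteric modulation of metabotropic glutamate receptor 5 (Homo sapiens), read by calcium flux; a lower number here means a smaller maximal response, a higher number a larger maximal response:
compound 1 `COc1ccc(N2CCn3nc(COc4ccccc4)cc3C2=O)cc1`: 58%
compound 2 `O=C1c2cc(COc3ccccc3)nn2CCN1c1ccccn1`: 69%
compound 3 `O=C1c2cc(COc3ccccc3F)nn2CCN1c1ccc(F)cc1`: 66%

Compound 3 sits within the scatter of both compound 2 and compound 1, so the three maximal responses cannot be ranked against each other. For the measured compounds named here, the only step that is beyond the scatter is a number 11 percentage points higher from compound 1 to compound 2 (beyond the scatter), and it concerns the aryl group on the amide-type nitrogen in a ring, not the ether side.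

Compound 4 `O=C1c2cc(COc3ccc(F)cn3)nn2CCN1c1ccc(F)cc1` differs from compound 3 as follows: 5-fluoropyridin-2-yl in place of 2-fluorophenyl on an oxygen on a saturated carbon. Going by the values given here, no measured pair exchanges a phenyl for a pyridinyl ring at this oxygen, so nothing bears directly on the step. The expectation for the step in this assay is therefore no change at the digits printed from compound 3 to compound 4 (within the scatter), a change not beyond the scatter. Compound 4 is estimated at 66%, with a range from 52% to 80%.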

Compound 4, largest response reached (Emax), in percent of the reference or control that the assay uses: 52%
For compound 4 the middle estimate is 14 percentage points above the measured one; the range from low to high includes it.
By their numbers in this assay, from the lowest: compounds 4, 1, 3 and 2 (each within the scatter of the next, the first and the last beyond it).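

In this assay the group on an oxygen on a saturated carbon does affect the maximal response: the step of a number 14 percentage points lower from compound 3 to compound 4 (beyond the scatter) is the only one shown at this place. It changes the ring atoms and the place of the fluorine at once, and the entering 5-fluoropyridin-2-yl carries a hydrogen-bond acceptor that the leaving 2-fluorophenyl lacks. No available evidence accounts for the lower response.

From the compounds shown here alone, whether the ring nitrogen or the fluorine place drives the step remains open. A plain pyridin-2-yl or a 4-fluorophenyl on this oxygen would separate the two.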